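The source may hold more compounds than are shown below. What is called first, only, known or untested is meant among the compounds shown, and "the series" means these compounds.

Compound 1 `COc1ccc(/C=C/c2cc(OC)cc(OC)c2/C=C/C(=O)c2ccc(N)cc2)cc1` and compound 2 `COc1ccc(/C=C/c2cc(OC)cc(OC)c2/C=C/C(=O)c2cccc(Cl)c2)cc1` share one core and differ only in the aryl group on the carbonyl carbon. In a functional assay on B16-F10 cells (Mus musculus) for antiproliferative activity, read by MTT assay, with a stated time of 48 h (on this read-out higher numbers stand for weaker inhibition and lower numbers for stronger inhibition), compound 1 gives 2.8 ug/mL. Compound 2 gives 3.3 ug/mL in this assay, which is within the scatter of compound 1. The step of a 1.2-fold higher number from compound 1 to compound 2 (0.07 log units; within the scatter) shows that swapping this aryl group left the read-out essentially unchanged. Compound 3 `COc1ccc(/C=C/c2cc(OC)cc(OC)c2/C=C/C(=O)c2ccc(-c3ccccc3)cc2)cc1` carries the change (4-phenylphenyl in place of 3-chlorophenyl on a carbonyl carbon). Going by the values given here, only the step from compound 1 to compound 2 bears on this, and it was within the scatter, so the estimate for a 1.1-fold higher number from compound 2 to compound 3 (0.03 log units; within the scatter) is no change beyond the scatter. Compound 3 is thus expected near 3.5 ug/mL, range 1.6 ug/mL to 8 ug/mL.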

Compound 3, half-maximal inhibitory concentration: 10.6 ug/mL
Compound 3: the middle estimate sits 3.0-fold (0.48 log units) below what was measured, and the stated range ends below it.
By their numbers in this assay, from the lowest: compounds 1 and 2 (each within the scatter of the next); then compound 3.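

On the aryl group at the carbonyl carbon, the read-out in this assay does respond to the group: 4-phenylphenyl gives a modest loss beyond the scatter (a 3.2-fold higher number from compound 2 to compound 3 (0.51 log units; beyond the scatter); a 3.8-fold higher number from compound 1 to compound 3 (0.58 log units; beyond the scatter)), unlike the earlier swap between 4-aminophenyl and 3-chlorophenyl. Among these three compounds, weaker inhibition appears only with the two-ring group, and phenyl in place of amino on an aromatic carbon is enough to produce it. No measurement shown explains this step.

Open, on these data alone, is whether plain phenyl or naphthyl at this position would stay level with compound 1 and compound 2.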